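Compound 2 to compound 3: amino in place of hydroxy

The source may hold more compounds than are shown below. What is called first, only, known or untested is meant among the compounds shown, and "the series" means these compounds.

In a functional assay on PC-3 cells (Homo sapiens) for cytotoxicity, read by trypan blue exclusion, with a stated time of 96 h (on this read-out lower numbers stand for stronger inhibition of growth and higher numbers for weaker inhibition of growth), compound 1 `COc1ccc(NS(=O)(=O)/C=C/c2c(OC)cc(OC)cc2OC)cc1` gives 100 nM, while compound 2 `COc1cc(OC)c(/C=C/S(=O)(=O)Nc2ccc(OC)c(O)c2)c(OC)c1` gives 25 nM, the lowest of the two numbers. Compound 3 `COc1cc(OC)c(/C=C/S(=O)(=O)Nc2ccc(OC)c(N)c2)c(OC)c1` is unmeasured and carries amino in place of hydroxy on an aromatic carbon, ortho to a methoxy group: amino in place of hydroxy on an aromatic carbon. Among the compounds with values here, the only guide is the modest 4.0-fold lower number from compound 1 to compound 2 (0.60 log units; beyond the scatter), with hydroxy in place of hydrogen on an aromatic carbon. Within the data shown here, no measured step tests amino, so no step beyond the scatter is expected in this assay. The expected change is a 1.3-fold lower number from compound 2 to compound 3 (0.10 log units; within the scatter). The estimate for compound 3 is 20 nM, with an expected range of 6 nM to 70 nM.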

Compound 3, concentration for 50% growth inhibition: 8 nM
Beside the measured number, compound 3's estimate is 2.5-fold (0.40 log units) above it; measured number inside the range.
By their numbers in this assay, from the lowest: compound 3; then compound 2; then compound 1.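

In this assay, the position responds to which group fills it, not only to its being filled: there is a 3.1-fold lower number from compound 2 to compound 3 (0.49 log units; beyond the scatter) when amino replaces hydroxy. Measured against hydrogen at the same place, amino gives a 13-fold lower number from compound 1 to compound 3 (1.10 log units; beyond the scatter) and so a large step, where hydroxy gave a modest one. Nothing measured here accounts for the difference between amino and hydroxy.

Open, as far as these compounds go, is whether an acetamido group, a methylamino group or a carboxylic acid at this position would keep the gain, and whether the neighbouring methoxy group can be changed while amino stays.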